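Difluoromethoxy on the Aromatic Ring of Compound 1

The source may report more compounds than this note shows. Statements on the series, on what has been measured and on what is new or still open speak of the compounds shown alone.

Compound 1 `Cc1ncccc1-c1nc2cn(-c3ccccc3)nc2c(=O)n1C[C@H]1CCCN(C[C@H]2CCCO2)C1` is examined in an assay on HEK293 cells for displacement of a labelled ligand from growth hormone secretagogue receptor type 1 (Homo sapiens), with a stated time of 60 min (a higher number here means a weaker inhibitor, a lower number a stronger inhibitor), where compound 1 gives 190 nM. This is the highest of the three numbers shown. Compound 2 `CCO[C@H](C)CN1CCC[C@H](Cn2c(-c3cccnc3C)nc3cn(-c4cccc(OC)c4)nc3c2=O)C1` gives 40 nM in this assay, and compound 3 `COc1cccc(-n2cc3nc(-c4cccnc4C)n(C[C@H]4CCCN(CC(C)C)C4)c(=O)c3n2)c1` gives 5.7 nM in this assay. Compound 2 and compound 3 share the same aromatic ring bearing methoxy, and between them the change a 7.0-fold lower number from compound 2 to compound 3 (0.85 log units; beyond the scatter) concerns only the group on the saturated chain carbon bound to the ring amine nitrogen.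

Compound 4 `Cc1ncccc1-c1nc2cn(-c3cccc(OC(F)F)c3)nc2c(=O)n1C[C@H]1CCCN(C[C@H]2CCCO2)C1` differs from compound 1 in one place: difluoromethoxy in place of hydrogen on an aromatic carbon. Read one bond further out, the change is phenyl to 3-(difluoromethoxy)phenyl, on the aromatic carbon that is meta to a large group. Among the measured compounds shown here, no measured step covers exactly this change. For the measured compounds named here, compound 1 and compound 2 differ in two places, so their values show only that the pair with the substituted ring sits lower, and the step from compound 2 to compound 3 does not touch the aromatic ring at all. A step downward of moderate size is therefore expected, with wide uncertainty. Compound 4 is estimated at 60 nM in this assay, within a range from 20 nM to 200 nM, an expected step of a 3.2-fold lower number from compound 1 to compound 4 (0.50 log units; beyond the scatter).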

Compound 4, half-maximal inhibitory concentration in the growth hormone secretagogue receptor type 1 assay: 27 nM
Beside the measured number, compound 4's estimate is 2.2-fold (0.35 log units) above it, within the range that was stated.
By their numbers in the growth hormone secretagogue receptor type 1 assay, from the lowest: compound 3; then compounds 4 and 2 (each within the scatter of the next); then compound 1.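

In the growth hormone secretagogue receptor type 1 assay, compound 1 and compound 4 form the first pair shown that differs only on the aromatic ring, and difluoromethoxy in place of hydrogen on this aromatic carbon, meta to a large group, gives a 7.0-fold lower number from compound 1 to compound 4 (0.85 log units; beyond the scatter). In a physicochemical assay for lipophilicity, using the shake flask method, measured as octanol-water partition, with a stated time of 30 min, at pH 7.4 (on this read-out lower numbers stand for lower lipophilicity and higher numbers for higher lipophilicity), compound 1 gives 1.7 and compound 4 gives 2.2. This single change therefore moves both read-outs, so the stronger inhibition of compound 4 comes with a measured rise in lipophilicity: the measured distribution coefficient of compound 1, 1.7, and of compound 4, 2.2, a number 0.50 log units higher (beyond the scatter)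

The compounds shown leave open whether a smaller or differently built group on this same aromatic carbon, such as fluorine, a nitrile or methoxy on the core and side chain of compound 1, would give a step of like size in either read-out. Among the compounds shown here, they also leave open whether difluoromethoxy would give a similar step on another carbon of the ring, or with another group on the ring amine nitrogen, such as the one carried by compound 3.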